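A few compounds are considered here, and "the series" means these few. Any claim that something is new, unique, unknown or untested is made for them only; others in the source may bear on it.

In a functional assay on HeLa cells for agonist activity at 5-hydroxytryptamine receptor 6 (Homo sapiens), read by immunoassay (on this read-out lower numbers stand for smaller maximal responses and higher numbers for larger maximal responses), compound 1 `CN(C)CCn1cc(S(=O)(=O)c2cc(Cl)cc(Cl)c2)c2cccnc21` gives 80% and compound 2 `CN(C)CCn1cc(S(=O)(=O)c2cccs2)c2cccnc21` gives 74%; the step of a number 6 percentage points lower from compound 1 to compound 2 (within the scatter) stays within the scatter. Compound 2 thus gives the smaller of the two numbers shown, with compound 1 within the scatter of it. Compound 3 `CN(C)CCn1cc(S(=O)(=O)c2ccc(Cl)s2)c2cccnc21` differs from compound 2 by chloro in place of hydrogen on an aromatic carbon, thiophen-2-yl becoming 5-chlorothiophen-2-yl. Going by the values given here, no measured step adds a chloro to that ring; the one measured step, exchanging the whole group on the sulfonyl sulfur, stayed within the scatter. In this assay the step of a number 1 percentage points higher from compound 2 to compound 3 (within the scatter) is therefore expected to stay within the scatter. Compound 3 is estimated at 75%, between 62% and 88%.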

Compound 3, largest response reached (Emax), in percent of the reference or control that the assay uses: 93%
Compound 3: the middle estimate sits 18 percentage points below what was measured; the measured number lies above the stated range.
By their numbers in this assay, from the lowest: compounds 2 and 1 (each within the scatter of the next); then compound 3.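

In this assay, chloro in place of hydrogen on the aromatic carbon next to the ring sulfur changes the maximal response, giving a number 19 percentage points higher from compound 2 to compound 3 (beyond the scatter). Exchanging the whole group on the sulfonyl sulfur also now gives a step beyond the scatter, a number 13 percentage points higher from compound 1 to compound 3 (beyond the scatter), so 5-chlorothiophen-2-yl stands apart from both 3,5-dichlorophenyl and thiophen-2-yl. No available evidence accounts for these steps.

Open, as far as these compounds go, is whether bromo, methyl or methoxy on the same ring carbon would give a comparable step. Also open, from the compounds shown here alone, is whether chloro on another carbon of that ring would do so.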